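A few compounds are considered here, and "the series" means these few. Any claim that something is new, unique, unknown or untested is made for them only; others in the source may bear on it.

Measured compounds in an assay for inhibition of Amine oxidase [flavin-containing] A (Homo sapiens), read by fluorescence, using microsomes, with a stated time of 30 min, tested at 10 uM; a higher number here means more inhibition at the concentration tested (going by the name of the read-out), a lower number less inhibition:

compound 1 `CN(C)Cc1ccc(COc2ccc3c(CO)cc(=O)oc3c2)cc1` gives 20%
compound 2 `CN(C)Cc1cccc(COc2ccc3c(CO)cc(=O)oc3c2)c1` gives 42%
compound 3 `Cc1c(C)c2ccc(OCC3CCN(CCCCO)CC3)cc2oc1=O` gives 30%

Compound 3 stands second highest of the three numbers. Its nearest neighbour is compound 1, whose number lies within the usual scatter of that of compound 3, so the two cannot be told apart. Compound 2 gives a higher number than compound 3, and that gap lies beyond the scatter. Compound 3 is the only one of the three that carries the shared core with the saturated ring and chain, so compound 1 and compound 2 give no direct guide to changes on that chain.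

Compound 4 `Cc1c(C)c2ccc(OCC3CCN(CCCO[N+](=O)[O-])CC3)cc2oc1=O` has not yet been measured. It differs from compound 3 in one place: nitrooxy in place of hydroxymethyl on a saturated chain carbon, three bonds along the chain from an amine nitrogen in a ring. Among the measured compounds shown here, no measured pair shows this change, so its effect is unknown. Given the modest number of compound 3 in this assay and the absence of any comparable pair, a small step is expected, a number 3 percentage points higher from compound 3 to compound 4 (within the scatter), in either direction or none beyond the scatter. Compound 4 is expected to give 33%, with a range from 15% to 55%.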

Compound 4, a percentage reported as inhibition, at one concentration (the size of the read-out at that concentration, not a potency): 36%
Compound 4: the middle estimate sits 3 percentage points below what was measured; low and high end bracket the measured number.
By their numbers in this assay, from the lowest: compounds 1, 3, 4 and 2 (each within the scatter of the next, the first and the last beyond it).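

At this place on the chain, three bonds along from an amine nitrogen in a ring, nitrooxy in place of hydroxymethyl gives a number 6 percentage points higher from compound 3 to compound 4 (within the scatter) in this assay. The 4-hydroxybutyl to 3-(nitrooxy)propyl exchange therefore goes from 1 hydrogen-bond donor and 1 hydrogen-bond acceptor in the leaving group to 0 donors and 3 acceptors in the entering group, and the read-out does not separate the two compounds. Nothing at hand offers an explanation for this result.

From the compounds shown here alone, whether a carboxylic acid, a primary amine or a longer chain at this position would separate from compound 3 remains open. Going by these compounds, with one pair at one concentration, it also remains open whether the same exchange behaves alike on another core or whether the two compounds differ in potency.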